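Chloro to Methoxy on the Aryl Ring of Compound 3

The compounds below may be only part of what the source reports. "The series", "measured", "known", "first", "only" and "open" are said of these compounds alone.

Compound 3 `N#C/C(=C\c1ccc(Cl)cc1)C(=O)NCc1ccc(Cl)c(Cl)c1` is the only one of the three with a number in a functional assay on NCI-H460 cells (Homo sapiens) for inhibition, read by MTT assay, with a stated time of 72 h; a higher number here means a weaker inhibitor of growth, a lower number a stronger inhibitor of growth: compound 3 gives 33000 nM. Compound 1 `N#C/C(=C\c1ccc[nH]1)C(=O)NCc1ccc(Cl)c(Cl)c1` reaches only the assay limit, > 50000 nM. Compound 2 `N#C/C(=C\c1ccco1)C(=O)NCc1ccc(Cl)c(Cl)c1` likewise sits at the limit, > 50000 nM. Compound 4 `COc1ccc(/C=C(\C#N)C(=O)NCc2ccc(Cl)c(Cl)c2)cc1` differs from compound 3 by methoxy in place of chloro on an aromatic carbon. The measured steps exchange the whole ring on the double-bonded chain carbon: an at least 1.5-fold lower number from compound 1 to compound 3 (0.18 log units; that floor lies within the scatter), an at least 1.5-fold lower number from compound 2 to compound 3 (0.18 log units; that floor lies within the scatter), and a step that the two limits leave unreadable from compound 1 to compound 2. Among the compounds with values here, none of them alters a single substituent on the 4-chlorophenyl ring, so no measured step bears directly on this change, and with the limit of > 50000 nM in this assay, at which 2 of the 3 values shown sit, two of the three values stay unreadable. The chemist therefore expects a step near zero, a 1.2-fold higher number from compound 3 to compound 4 (0.08 log units; within the scatter), possibly running into the limit. The chemist estimates compound 4 at 40000 nM, ranging from 15000 nM to 100000 nM.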

Compound 4, concentration for 50% growth inhibition: > 100000 nM
Compound 4 gave a limit, no number; the forecaster's own chance of this, stated with the estimate: 40%; middle value at least 2.5-fold (0.39 log units) away from the limit.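

In this assay, methoxy in place of chloro on the aromatic carbon para to a large group gives an at least 3.0-fold higher number from compound 3 to compound 4 (0.48 log units; beyond the scatter), the only step shown that changes a substituent on this ring while leaving the ring itself in place. Compound 4 gives > 100000 nM, which is a limit of the assay and not a number, so this step gives only a floor. The steps to compound 4 from compound 1 and from compound 2 cannot be read.

On these data alone, whether an amine or a hydroxyl group at this position would give a lower number than compound 3 stays open.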